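A few compounds are considered here, and "the series" means these few. Any claim that something is new, unique, unknown or untested is made for them only; others in the source may bear on it.

Two compounds of this series carry a measured number. Compound 1 `O=[N+]([O-])c1ccc2[nH]c(CSCc3nc4ccccc4[nH]3)nc2c1` gives 7910 nM in a functional assay on HCT-116 cells (Homo sapiens) for cytotoxicity, read by MTT assay, with a stated time of 48 h; a lower number here means a stronger inhibitor, a higher number a weaker inhibitor. Compound 2 `O=C(CSCc1nc2cc([N+](=O)[O-])ccc2[nH]1)c1ccc(Br)cc1` gives 1780 nM in the same assay, the lowest of the two numbers, and the gap to compound 1 lies beyond the usual scatter. Compound 3 `NC(=O)CSCc1nc2cc([N+](=O)[O-])ccc2[nH]1` differs from compound 2 by amino in place of 4-bromophenyl on a carbonyl carbon. Among the compounds with values here, no step of this kind appears elsewhere among the measured compounds, so the direction rests on the change alone; a weaker inhibitor is expected, with the step of a 9.0-fold higher number from compound 2 to compound 3 (0.95 log units; beyond the scatter) estimated as beyond the scatter. Compound 3 is thus estimated at 16000 nM, within 4000 nM to 60000 nM.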

Compound 3, half-maximal inhibitory concentration: 17200 nM
Compound 3: middle estimate off by 1.1-fold (0.03 log units), on the low side; measured number inside the range.
By their numbers in this assay, from the lowest: compound 2; then compound 1; then compound 3.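

Within the data shown here, on the carbonyl carbon, amino in place of 4-bromophenyl gives a 9.7-fold higher number from compound 2 to compound 3 (0.99 log units; beyond the scatter) in this assay, the first step that changes one place only. The result shows that this position does not tolerate every group equally: the higher number goes with the loss of the aromatic ring and the bromine. No measurement here accounts for the step.

Going by these compounds, whether the ring or the bromine matters remains open; plain phenyl would separate the two. Methyl or dimethylamino on the same carbonyl carbon would show how the series behaves with other non-aromatic groups.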